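Methoxy-cinnamate esters: adding a second methoxy on the ring

The source may hold more compounds than are shown below. What is called first, only, known or untested is meant among the compounds shown, and "the series" means these compounds.

Measured so far:
- compound 1 `COc1ccccc1/C=C/C(=O)OCc1nc(C)c(C)nc1C`: < 24000 nM
- compound 2 `COc1cccc(/C=C/C(=O)OCc2nc(C)c(C)nc2C)c1`: < 24000 nM
- compound 3 `COc1ccc(/C=C/C(=O)OCc2nc(C)c(C)nc2C)cc1`: < 24000 nM

In a functional assay on PC-12 cells (Rattus norvegicus) (on this read-out higher numbers stand for an effect only at larger amounts of compound and lower numbers for an effect already at smaller amounts), compound 1 reports only a limit, < 24000 nM. In this assay compound 2 likewise reports only a limit, < 24000 nM. Compound 3 also reports only a limit in this assay, < 24000 nM. So compound 3 has no number of its own to stand on, and the two other values shown are limits as well; all three sit at the same point, (the limit of < 24000 nM in this assay, at which 3 of the 3 values shown sit). Among the measured compounds shown here, no step between measured compounds is available, since none of the pairs has two numbers to compare.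

The next compound, compound 4 `COc1ccc(/C=C/C(=O)OCc2nc(C)c(C)nc2C)cc1OC`, differs from compound 3 by methoxy in place of hydrogen on an aromatic carbon; the new methoxy sits ortho to a methoxy group and meta to a large group. With nothing but limits shown, no step beyond the scatter is expected, and the expected step from compound 3 to compound 4 is a step that the limit leaves unreadable from compound 3 to compound 4. Compound 4 is therefore expected to give about 10000 nM in this assay, within a range of 2000 nM to 24000 nM, most likely again reported only as a limit.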

Compound 4, half-maximal effective concentration: < 24000 nM
Compound 4: no number, only a limit (the forecaster's own chance of this, stated with the estimate: 70%); the middle value does not contradict the limit.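

In this assay compound 4 reports only a limit, < 24000 nM. No step from compound 2 or compound 3 to compound 4 can be read, as all values shown are limits: the limit of < 24000 nM in this assay, at which 4 of the 4 values shown sit.

From the compounds shown here alone, whether the added methoxy shifts the half-maximal effective concentration at all, and how these esters rank, stays open.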